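A Ring at the Alkyne Terminus: Estimating Compound 4

A few compounds are considered here, and "the series" means these few. Any claim that something is new, unique, unknown or untested is made for them only; others in the source may bear on it.

Three measured compounds share one core and differ only in the group carried past the triple bond. Compound 1 `NC(=O)c1cc(Cl)c2c(Cl)c(C#CCO)n([C@H]3CCCNC3)c2n1` bears a hydroxy group on the saturated chain carbon bound to a triple-bonded carbon, and in a functional assay on KG-1 cells (Homo sapiens) for antiproliferative activity (on this read-out higher numbers stand for an effect only at larger amounts of compound and lower numbers for an effect already at smaller amounts), compound 1 gives 301 nM. Compound 2 `NC(=O)c1cc(Cl)c2c(Cl)c(C#CCCO)n([C@H]3CCCNC3)c2n1` gives 56 nM, and compound 3 `NC(=O)c1cc(Cl)c2c(Cl)c(C#CCN3CCCC3=O)n([C@H]3CCCNC3)c2n1` gives 178 nM. Compound 3 thus holds the second highest of the three numbers: the step of a 1.7-fold lower number from compound 1 to compound 3 (0.23 log units; within the scatter) keeps it within the scatter of compound 1, while the step of a 3.2-fold higher number from compound 2 to compound 3 (0.50 log units; beyond the scatter) places it beyond the scatter from compound 2. The step of a 5.4-fold lower number from compound 1 to compound 2 (0.73 log units; beyond the scatter) completes the series.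

Compound 4 `NC(=O)c1cc(Cl)c2c(Cl)c(C#CC3CCOCC3)n([C@H]3CCCNC3)c2n1` alters this end once more: oxan-4-yl in place of (2-oxopyrrolidin-1-yl)methyl on a triple-bonded carbon. Among the measured compounds shown here, none of the measured steps swaps a group on the saturated chain carbon for a ring sitting directly on the triple-bonded carbon, so they bear on this move only loosely; what they show is that changes at this end move the number by modest amounts in either direction, staying between the values of compound 1 and compound 2. A step of that size, in either direction, is therefore expected for a 1.2-fold lower number from compound 3 to compound 4 (0.07 log units; within the scatter). Compound 4 is accordingly estimated at 150 nM, with a range from 50 nM to 500 nM.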

Compound 4, half-maximal effective concentration: 69 nM
The estimate for compound 4 lay 2.2-fold (0.34 log units) above the measured number; the measured number falls inside the stated range.
By their numbers in this assay, from the lowest: compounds 2 and 4 (each within the scatter of the next); then compounds 3 and 1 (each within the scatter of the next).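

In this assay, oxan-4-yl in place of (2-oxopyrrolidin-1-yl)methyl on a triple-bonded carbon gives a 2.6-fold lower number from compound 3 to compound 4 (0.41 log units; beyond the scatter), although both groups have the same hydrogen-bond donor and acceptor counts and no net charge, so those counts do not account for the difference. The position therefore accepts a ring set directly on the triple-bonded carbon: the change from hydroxymethyl gives a 4.4-fold lower number from compound 1 to compound 4 (0.64 log units; beyond the scatter), and the change from 2-hydroxyethyl gives a 1.2-fold higher number from compound 2 to compound 4 (0.09 log units; within the scatter), so compound 2 is no longer alone at the low end of the series. No measurement shown here explains why these groups differ.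

From compound 3 to compound 4, the saturated chain carbon, the ring size, the ring nitrogen and the carbonyl all change together, so the compounds shown cannot say which of these changes carries the step. They also leave open how oxan-4-ylmethyl, with its ring held one carbon further out, or a cyclohexyl ring, a piperidin-4-yl ring or a carboxylic acid on a triple-bonded carbon would read in this assay.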